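This account rests on a few compounds, and the source may have more. Where it says the series, first, only, none or still open, it means among the compounds named here.

Compound 1 `CCn1c(=O)n(C2OC(CO)[C@@H](O)[C@H]2O)c2nc(N)nc(O)c21` is the reference point of this set. In a functional assay on the whole organism (B cells) with Mus musculus as the target (a higher number here means a larger maximal response, a lower number a smaller maximal response), compound 1 gives 82%, the higher of the two numbers recorded so far. Among the measured compounds shown here, compound 2 `C=CCn1c(=O)n(C2OC(CO[Si](c3ccccc3)(c3ccccc3)C(C)(C)C)[C@@H](O)[C@H]2O)c2nc(N)nc(O)c21` differs from compound 1 in more than one place, so no single step links them; in this assay compound 2 gives 33%, a number well below that of compound 1 and outside the usual scatter.

Compound 3 `N#Cc1cccc(Cn2c(=O)n(C3OC(CO)[C@@H](O)[C@H]3O)c3nc(N)nc(O)c32)c1` has not yet been measured. Its difference from compound 1 is 3-cyanophenyl in place of methyl on a saturated chain carbon bound to an aromatic nitrogen. For the measured compounds named here, no measured pair shows this change on its own, and the drop from compound 1 to compound 2 cannot be assigned to one change, so the expected direction is uncertain. The step from compound 1 to compound 3 in this assay is estimated as a number 22 percentage points lower from compound 1 to compound 3 (beyond the scatter), a moderate decrease. Compound 3 is expected to give about 60% in this assay, within a range from 30% to 90%.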

Compound 3, largest response reached (reported as maximal response), in percent of the reference or control that the assay uses: 16%
Compound 3: middle estimate off by 44 percentage points, on the high side; the whole stated range lies above it.
By their numbers in this assay, from the lowest: compound 3; then compound 2; then compound 1.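

The position on the saturated chain carbon bound to an aromatic nitrogen now has its first single-place reading: in this assay, 3-cyanophenyl in place of methyl gives a number 66 percentage points lower from compound 1 to compound 3 (beyond the scatter). The maximal response therefore depends strongly on the group at this place, even with the rest of the core of compound 1 unchanged. No supporting data on hand account for the loss.

The compounds shown do not separate the contribution of the phenyl ring from that of the nitrile, so it stays open how an unsubstituted phenyl, a longer alkyl chain such as propyl, or an amine at this place would read in this assay. The value of compound 2 still cannot be assigned to any one of its changes.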